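Nitro for Methyl on the Thione Analogue

A few compounds are considered here, and "the series" means these few. Any claim that something is new, unique, unknown or untested is made for them only; others in the source may bear on it.

In an assay for inhibition of Amine oxidase [flavin-containing] A (Rattus norvegicus) (on this read-out lower numbers stand for stronger inhibition and higher numbers for weaker inhibition), compound 3 `Cc1cccc(COc2ccc(-c3nn(CCC#N)c(=S)o3)cc2)c1` gives 14000 nM. Compound 2 `N#CCCn1nc(-c2ccc(OCc3ccc([N+](=O)[O-])cc3)cc2)oc1=O` gives 11000 nM, and compound 1 `Cc1ccc(COc2ccc(-c3nn(CCC#N)c(=O)o3)cc2)cc1` gives 25000 nM; both of these lie within the usual scatter of compound 3, so no order among the three can be read from these numbers. Compound 4 `N#CCCn1nc(-c2ccc(OCc3ccc([N+](=O)[O-])cc3)cc2)oc1=S` has not yet been measured; it differs from compound 3 by 4-nitrophenyl in place of 3-methylphenyl on a saturated chain carbon bound to an oxygen on an aromatic ring. Within the data shown here, the one measured step that bears on this change is a 2.3-fold lower number from compound 1 to compound 2 (0.36 log units; beyond the scatter), a related swap carried out on the analogues of compound 3 and compound 4. Compound 4 is therefore expected to give a modestly lower number, estimated as a 2.2-fold lower number from compound 3 to compound 4 (0.33 log units; beyond the scatter). The estimate for compound 4 is 6500 nM, with a range from 3000 nM to 15000 nM.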

Compound 4, half-maximal inhibitory concentration: 2600 nM
For compound 4 the middle estimate is 2.5-fold (0.40 log units) above the measured one; the whole stated range lies above it.
By their numbers in this assay, from the lowest: compound 4; then compounds 2, 3 and 1 (each within the scatter of the next, the first and the last beyond it).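

In this assay, the exchange of 3-methylphenyl for 4-nitrophenyl on the thione compounds gives a 5.4-fold lower number from compound 3 to compound 4 (0.73 log units; beyond the scatter). The lowering already seen on the carbonyl compounds, a 2.3-fold lower number from compound 1 to compound 2 (0.36 log units; beyond the scatter), therefore also appears with the thione, and this is the lowest number among the compounds shown. Nothing available explains why the nitro-bearing compounds give lower numbers.

Since both the substituent and its printed ring position differ between compound 3 and compound 4, their separate contributions remain unresolved. Going by these compounds, it also remains open whether an amine or a carboxylic acid on that ring would lower the number.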